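A few compounds are considered here, and "the series" means these few. Any claim that something is new, unique, unknown or untested is made for them only; others in the source may bear on it.

Measured so far:
- Compound 1, `CCN(CC#CC#CC(C)(C)OC)Cc1cccc(OC[Si](C)(C)c2ccccc2C)c1`: 70 nM
- Compound 2, `CCN(C/C=C/C#CC(C)(C)C)Cc1cccc(OC[Si](C)(C)c2ccc(F)cc2)c1`: 60 nM
- Compound 3, `CCN(C/C=C/C#CC(C)(C)C)Cc1cccc(OC[Si](C)(C)c2ccc(OC)cc2)c1`: 870 nM

In a functional assay on liver (Sus scrofa) for inhibition of squalene monooxygenase (Homo sapiens), using microsomes (on this read-out higher numbers stand for weaker inhibition and lower numbers for stronger inhibition), compound 3 gives 870 nM, the highest number of the three. Compound 1 sits at 70 nM and compound 2 at 60 nM, so both lie well below compound 3, and the gap to each is beyond the scatter. Among the measured compounds shown here, the single step within the measured set is a 15-fold higher number from compound 2 to compound 3 (1.16 log units; beyond the scatter), which is the change that separates compound 2 from compound 3 and is the only measured step on the aryl group attached to silicon.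

Compound 4, `CCN(C/C=C/C#CC(C)(C)C)Cc1cccc(OC[Si](C)(C)c2ccccc2C(F)(F)F)c1`, has not yet been measured. It differs from compound 3 by 2-(trifluoromethyl)phenyl in place of 4-methoxyphenyl on a silicon. For the measured compounds named here, the step that bears on it is the one from compound 2 to compound 3: the methoxy-bearing aryl group, which goes with the weakest inhibition, is removed here. Compound 1, carrying a 2-methylphenyl on silicon with a different chain, gives 70 nM, which suggests a group on the aromatic ring at that position is compatible with strong inhibition. The step is therefore expected to run downward, roughly reversing the step from compound 2 to compound 3, so that compound 4 is estimated at 80 nM, between 30 nM and 250 nM, a step of an 11-fold lower number from compound 3 to compound 4 (1.04 log units; beyond the scatter).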

Compound 4, half-maximal inhibitory concentration: 70 nM
Compound 4: the middle estimate sits 1.1-fold (0.06 log units) above what was measured; measured number inside the range.
By their numbers in this assay, from the lowest: compounds 2, 1 and 4 (each within the scatter of the next); then compound 3.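

In this assay, among the compounds shown here, the earlier compounds showed only that 4-methoxyphenyl on a silicon goes with a much higher number than 4-fluorophenyl, and the new compound shows that this high number is not shared by every substituted aryl group at this place. Putting 2-(trifluoromethyl)phenyl in place of 4-methoxyphenyl gives a 12-fold lower number from compound 3 to compound 4 (1.09 log units; beyond the scatter), even though the entering group holds more heavy atoms than the one leaving, so among these two compounds a larger count of heavy atoms does not go with a higher number. Against 4-fluorophenyl the same group gives a 1.2-fold higher number from compound 2 to compound 4 (0.07 log units; within the scatter), so two aryl groups with different substituents are indistinguishable here and compound 3 alone stands apart; nothing given here accounts for that difference.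

As far as these compounds go, what remains open is whether the high number of compound 3 belongs to the methoxy group itself or to where it sits on the ring, and whether an amine or a hydroxyl on that aryl group would behave like the methoxy. Compound 1 also differs in its chain, so it cannot settle either question.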